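This account rests on a few compounds, and the source may have more. Where it says the series, first, only, none or still open, it means among the compounds named here.

Measured compounds in a functional assay on K562 cells (Homo sapiens) for cytotoxicity, read by CCK-8 assay, with a stated time of 72 h; on this read-out higher numbers stand for weaker inhibition and lower numbers for stronger inhibition:
compound 1 `COc1ccccc1/C=c1/[nH]c(=O)/c(=C\c2ccccc2OC)n(C)c1=O` gives 2200 nM
compound 2 `C=CCn1c(=O)/c(=C\c2cccc(F)c2)[nH]c(=O)/c1=C\c1ccccc1OC` gives 4100 nM
compound 3 `C=CCn1c(=O)/c(=C\c2cccc(Cl)c2Cl)[nH]c(=O)/c1=C\c1ccccc1OC` gives 900 nM

Among these three, compound 2 carries the highest number in this assay. Compound 1 sits close to it, and the gap between the two lies within the usual scatter, so nothing can be said about an order between them. Compound 3 stands apart: the step of a 4.6-fold lower number from compound 2 to compound 3 (0.66 log units; beyond the scatter) is beyond the scatter.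

Compound 4 `C=CCn1c(=O)/c(=C\c2ccc(Cl)c(Cl)c2)[nH]c(=O)/c1=C\c1ccccc1OC` differs from compound 2 by 3,4-dichlorophenyl in place of 3-fluorophenyl on a double-bonded chain carbon bound to an aromatic carbon. Going by the values given here, the one measured step that bears on this change is a 4.6-fold lower number from compound 2 to compound 3 (0.66 log units; beyond the scatter), where a dichlorophenyl likewise took the place of the 3-fluorophenyl on the double-bonded chain carbon bound to an aromatic carbon. Among the compounds with values here, no measured pair separates the 3,4-dichlorophenyl from the 2,3-dichlorophenyl, so the size of that step is the only guide, and the expectation is tempered for the untested pattern.

A lowering of the number beyond the scatter is therefore expected for compound 4, somewhat smaller than the step seen for compound 3. Compound 4 is estimated at 1300 nM in this assay, with a range from 450 nM to 3800 nM. This corresponds to an expected step of a 3.2-fold lower number from compound 2 to compound 4 (0.50 log units; beyond the scatter).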

Compound 4, half-maximal inhibitory concentration: "not active" (no number reported)
Compound 4: no number reported; the estimate stays without a comparison.
By their numbers in this assay, from the lowest: compound 3; then compounds 1 and 2 (each within the scatter of the next).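

In this assay, going by these compounds alone, compound 4 is recorded as "not active" with no number, so no step from compound 2 to compound 4 can be read. Nothing shown here bears on the reason for this result. The compounds shown leave open how the 3,4-dichlorophenyl of compound 4 compares in number with the 2,3-dichlorophenyl of compound 3.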